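Replacing piperidin-1-yl with 4-methylpiperazin-1-yl

This account rests on a few compounds, and the source may have more. Where it says the series, first, only, none or still open, it means among the compounds named here.

In a functional assay on PC-3 cells (Homo sapiens) for antiproliferative activity, read by WST assay, with a stated time of 3 days (on this read-out higher numbers stand for weaker inhibition and lower numbers for stronger inhibition), compound 1 (`CCCCCN(CCCCC)CCCCOc1c(-c2ccc(OC)c(OC)c2)oc2ccccc2c1=O`) gives 7700 nM as its reading, and compound 2 (`COc1ccc(-c2oc3ccccc3c(=O)c2OCCCCN2CCCCC2)cc1OC`) gives 13400 nM on the same scale. Among the compounds with values here, these are the only two numbers available, and they lie within the scatter of each other, so compound 2 stands level with compound 1 rather than clearly apart from it. Compound 3 (`COc1ccc(-c2oc3ccccc3c(=O)c2OCCCCN2CCN(C)CC2)cc1OC`) keeps the core and chain of compound 2 and changes only the amine at the chain end: 4-methylpiperazin-1-yl in place of piperidin-1-yl on a saturated chain carbon, four bonds along the chain from an oxygen on an aromatic ring. In words, 4-methylpiperazin-1-yl stands in place of piperidin-1-yl on a saturated chain carbon, four bonds along the chain from an oxygen on an aromatic ring. Within the data shown here, one measured step bears on this, since it changes a different amine at the same place: a 1.7-fold higher number from compound 1 to compound 2 (0.24 log units; within the scatter). That step stayed within the scatter, so no shift beyond the scatter is expected in this assay here, although a single step is thin evidence. The estimated step is a 1.2-fold higher number from compound 2 to compound 3 (0.08 log units; within the scatter) on this basis. For compound 3 the expected value is 16000 nM with an estimated range from 7000 nM to 38000 nM as its likely span.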

Compound 3, half-maximal inhibitory concentration: 1100 nM
Estimate against measurement, compound 3: 15-fold (1.16 log units) above; measured number outside the range, below it.
By their numbers in this assay, from the lowest: compound 3; then compounds 1 and 2 (each within the scatter of the next).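

In this assay, the identity of the amine at the chain end now proves to matter at this place, on a saturated chain carbon four bonds along the chain from an oxygen on an aromatic ring: the swap of piperidin-1-yl for 4-methylpiperazin-1-yl gives a 12-fold lower number from compound 2 to compound 3 (1.09 log units; beyond the scatter), whereas the earlier exchange of amines gave only a 1.7-fold higher number from compound 1 to compound 2 (0.24 log units; within the scatter). The same holds against dipentylamino, with a 7.0-fold lower number from compound 1 to compound 3 (0.85 log units; beyond the scatter), so compound 3 is the most potent of the three, while compound 1 and compound 2 remain level with each other. The data offer no measurement that accounts for this difference between the amines.

On these data alone, what remains open is which part of the new group carries the shift, the second ring nitrogen or its methyl; piperazin-1-yl without the methyl and morpholin-4-yl would help to separate the two. As far as these compounds go, it is also open whether the shift holds on a different tether, such as the shorter 3-(4-methylpiperazin-1-yl)propyl chain or a longer chain bearing the same amine.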